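A few compounds are considered here, and "the series" means these few. Any claim that something is new, unique, unknown or untested is made for them only; others in the source may bear on it.

In a functional assay on MCF7 cells (Homo sapiens) for antiproliferative activity, read by MTT assay, with a stated time of 72 h (a higher number here means a weaker inhibitor, a lower number a stronger inhibitor), compound 1 `C=C(Br)C(=O)Nc1ccc2c(c1)/C(=C/c1cccs1)C(=O)N2` gives 1700 nM, and compound 2 `C=C(Br)C(=O)Nc1ccc2c(c1)/C(=C\c1cccs1)C(=O)N2` gives 2300 nM, so the two stand level within the usual scatter. Compound 3 `C=C(Br)C(=O)Nc1ccc2c(c1)/C(=C/c1ccc(C)s1)C(=O)N2` keeps the core of compound 1 but turns thiophen-2-yl into 5-methylthiophen-2-yl: methyl in place of hydrogen on an aromatic carbon. Within the data shown here, the only measured step is a 1.4-fold higher number from compound 1 to compound 2 (0.13 log units; within the scatter), and it comes with the fact that compounds 1 and 2 differ only in the configuration as drawn, so it tests no added group. No step beyond the scatter is therefore expected in this assay, in either direction. The expected change is a 1.1-fold lower number from compound 1 to compound 3 (0.05 log units; within the scatter). For compound 3 the estimate is 1500 nM, with an expected range of 600 nM to 4000 nM.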

Compound 3, half-maximal inhibitory concentration: 3000 nM
Estimate against measurement, compound 3: 2.0-fold (0.30 log units) below; the range from low to high includes it.
By their numbers in this assay, from the lowest: compounds 1, 2 and 3 (each within the scatter of the next).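

In this assay methyl in place of hydrogen on an aromatic carbon next to the ring sulfur gives a 1.8-fold higher number from compound 1 to compound 3 (0.25 log units; within the scatter) and so leaves compound 3 level with compound 1 within the scatter. Among these compounds, this is the first sign that this position accepts a small added group in this assay, which the earlier step could not give: the fact that compounds 1 and 2 differ only in the configuration as drawn. Going by these compounds, whether a longer chain such as ethyl or an amine at this carbon would also stay level remains open. So does whether methyl would behave the same way with the double bond drawn as in compound 2.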